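Imide to lactam change at the benzylidene position

The compounds below may be only part of what the source reports. "The series", "measured", "known", "first", "only" and "open" are said of these compounds alone.

Measured compounds:
compound 1 `CCc1cnc(N2CCC(c3nc(COc4ccc(/C=C5\CC(=O)N(CC6CCOCC6)C5=O)cc4F)cs3)CC2)nc1` — 240 nM
compound 2 `CCc1cnc(N2CCC(c3nc(COc4ccc(/C=C5\CC(=O)N(CCN)C5=O)cc4F)cs3)CC2)nc1` — "not determined" (no result reported)
compound 3 `CCc1cnc(N2CCC(c3nc(COc4ccc(/C=C5\CC(=O)N(CCNC(=O)OC(C)(C)C)C5=O)cc4F)cs3)CC2)nc1` — "not determined" (no result reported)

In a functional assay on cells for agonist activity at Glucose-dependent insulinotropic receptor (Homo sapiens), read by a luciferase reporter, with a stated time of 6 h (a lower number here means that less compound is needed, a higher number that more compound is needed for the effect), compound 1 gives 240 nM. Compound 2 has no number in this assay and stands as "not determined" (no result reported). Compound 3 likewise stands as "not determined" (no result reported), so one further entry in the series carries no single number. Compound 4 `CCc1cnc(N2CCC(c3nc(COc4ccc(/C=C5\CCNC5=O)cc4F)cs3)CC2)nc1` differs from compound 2 by a group of 7 heavy atoms (5 carbon, 1 nitrogen, 1 oxygen; one five-membered non-aromatic ring with 1 hetero atom) in place of a group of 11 heavy atoms (7 carbon, 2 nitrogen, 2 oxygen; one five-membered non-aromatic ring with 1 hetero atom), on an aromatic carbon. Among the measured compounds shown here, no pair of measured compounds shows a step of this kind, so its size cannot be read from the series; relative to compound 1 the shorter, less substituted ring is expected to cost a modest amount of potency in this assay, somewhat beyond the scatter. Compound 4 is estimated at 600 nM, with a range from 120 nM to 3000 nM.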

Compound 4, half-maximal effective concentration: 100 nM
Estimate against measurement, compound 4: 6.0-fold (0.78 log units) above; the whole stated range lies above it.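

Among the compounds shown here, with no number for compound 2 in this assay no step to compound 4 can be read. The compounds shown leave open what the change of ring alone does to potency. No measured evidence bears on this result.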